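Pyridin-2-yl in Place of Methyl on the Sulfur

This account rests on a few compounds, and the source may have more. Where it says the series, first, only, none or still open, it means among the compounds named here.

Among the compounds with values here, of the two numbers so far in an assay on isolated protein for inhibition of Polyunsaturated fatty acid 5-lipoxygenase (Rattus norvegicus) (a lower number here means a stronger inhibitor, a higher number a weaker inhibitor), compound 2 `CSC1CN(c2ccccc2)NC1=O` stands at 320 nM, and compound 1 `COCCOCC1CN(c2ccccc2)NC1=O` at 520 nM lies within the scatter of it, as the step of a 1.6-fold lower number from compound 1 to compound 2 (0.21 log units; within the scatter) shows. Compound 3 `O=C1NN(c2ccccc2)CC1Sc1ccccn1` carries pyridin-2-yl in place of methyl on a sulfur. Within the data shown here, the one measured step alters the group on the saturated ring carbon, not what sits on the sulfur, so it bears on this change only loosely and points in no direction. Compound 3 is therefore expected to show a 1.1-fold lower number from compound 2 to compound 3 (0.03 log units; within the scatter), nothing beyond the scatter. For compound 3 the estimate is 300 nM, with a range of 100 nM to 1000 nM.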

Compound 3, half-maximal inhibitory concentration: 120 nM
Beside the measured number, compound 3's estimate is 2.5-fold (0.40 log units) above it, within the range that was stated.
By their numbers in this assay, from the lowest: compound 3; then compounds 2 and 1 (each within the scatter of the next).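

Pyridin-2-yl in place of methyl on the sulfur gives the first step beyond the scatter in this assay, a 2.7-fold lower number from compound 2 to compound 3 (0.43 log units; beyond the scatter). The group on the sulfur is thus a place where this number responds, and a six-membered aromatic ring there goes with a lower number, not a higher one. No measurement at hand accounts for the size of this step. The compounds shown leave open whether the nitrogen of pyridin-2-yl matters or the ring alone does, as phenyl on the sulfur is not among them. They also leave open how an amine or a carboxylic acid on that ring would read.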